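Amide-nitrogen substituent variation on a shared core

The compounds below may be only part of what the source reports. "The series", "measured", "known", "first", "only" and "open" are said of these compounds alone.

Measured so far:
compound 1 `CCCNC(=O)/N=C(\N)NCCCc1sc(N)nc1C` — 105 nM
compound 2 `Cc1nc(N)sc1CCCN/C(N)=N/C(=O)N[C@@H](C)c1ccccc1` — 51.3 nM
compound 3 `CCCCCCNC(=O)/N=C(\N)NCCCc1sc(N)nc1C` — 28.8 nM
compound 4 `Cc1ccc(CC(C)CNC(=O)/N=C(\N)NCCCc2sc(N)nc2C)cc1` — not yet measured

In an assay on membranes from Sf9 cells for displacement of a labelled ligand from histamine H2 receptor (Homo sapiens), read by scintillation counting, with a stated time of 60 min (a lower number here means a stronger inhibitor, a higher number a weaker inhibitor), compound 1 stands highest of the three numbers; compound 2 lies nearest to it and compound 3 furthest. Compound 4 differs from compound 1 in one place: 4-methylbenzyl in place of hydrogen on a saturated chain carbon bound to two saturated chain carbons. Among the compounds with values here, two measured steps bear on this change. Extending the same chain gave a 3.6-fold lower number from compound 1 to compound 3 (0.56 log units; beyond the scatter), and an aryl-bearing group on the amide-type nitrogen gave a 2.0-fold lower number from compound 1 to compound 2 (0.31 log units; beyond the scatter). Both lowered the number, so a lower number is expected for compound 4, with a step of roughly a 3.0-fold lower number from compound 1 to compound 4 (0.48 log units; beyond the scatter) expected. The estimate for compound 4 in this assay is 35 nM, with a range from 12 nM to 100 nM.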

Compound 4, inhibition constant: 72.4 nM
Estimate against measurement, compound 4: 2.1-fold (0.32 log units) below; low and high end bracket the measured number.
By their numbers in this assay, from the lowest: compounds 3, 2, 4 and 1 (each within the scatter of the next, the first and the last beyond it).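

In this assay, 4-methylbenzyl in place of hydrogen on a saturated chain carbon bound to two saturated chain carbons gives a 1.5-fold lower number from compound 1 to compound 4 (0.16 log units; within the scatter), so this position carries a group with a six-membered aromatic ring without a change beyond the scatter. The earlier changes, a 3.6-fold lower number from compound 1 to compound 3 (0.56 log units; beyond the scatter) and a 2.0-fold lower number from compound 1 to compound 2 (0.31 log units; beyond the scatter), both lay beyond the scatter, and that lowering does not carry over to this change. Nothing on hand accounts for the result. As far as these compounds go, whether benzyl without the methyl, 4-methoxybenzyl or an aminomethyl group at this position would shift the number remains open.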